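Indole hydrazone ureas: 3,4-dichlorobenzyl analog of compound 3

The compounds below may be only part of what the source reports. "The series", "measured", "known", "first", "only" and "open" are said of these compounds alone.

Three compounds of this series have numbers in a functional assay on A549 cells (Homo sapiens) for cytotoxicity, read by MTT assay, with a stated time of 72 h; a higher number here means a weaker inhibitor, a lower number a stronger inhibitor. Compound 1 `CCN(CC)Cc1ccc2nc(NC(=O)N/N=C/c3cn(Cc4ccc(C)cc4)c4ccccc34)sc2c1` gives 1510 nM, compound 2 `CCN(CC)Cc1ccc2nc(NC(=O)N/N=C/c3cn(Cc4ccc(Cl)cc4Cl)c4ccccc34)sc2c1` gives 1900 nM, and compound 3 `CCN(CC)Cc1ccc2nc(NC(=O)N/N=C/c3cn(Cc4ccccc4)c4ccccc34)sc2c1` gives 3330 nM. Compound 3 therefore carries the highest of the three numbers; its nearest neighbour is compound 2, with a 1.8-fold higher number from compound 2 to compound 3 (0.24 log units; within the scatter), and its furthest is compound 1, with a 2.2-fold higher number from compound 1 to compound 3 (0.34 log units; beyond the scatter).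

Compound 4 `CCN(CC)Cc1ccc2nc(NC(=O)N/N=C/c3cn(Cc4ccc(Cl)c(Cl)c4)c4ccccc34)sc2c1` is not yet measured. Against compound 3 the change is 3,4-dichlorophenyl in place of phenyl on a saturated chain carbon bound to an aromatic nitrogen.

Going by the values given here, two measured steps bear on this change, both at the same place on the benzyl group. The step of a 1.3-fold higher number from compound 1 to compound 2 (0.10 log units; within the scatter) and the step of a 1.8-fold higher number from compound 2 to compound 3 (0.24 log units; within the scatter) both fall within the scatter, so chlorine substitution on this ring has so far not moved the number in a way that can be read. Among the compounds with values here, the one step beyond the scatter, a 2.2-fold higher number from compound 1 to compound 3 (0.34 log units; beyond the scatter), concerns methyl rather than chlorine. Compound 4 is therefore expected to give a number close to compound 3, with at most a small drop, so that the step of a 1.5-fold lower number from compound 3 to compound 4 (0.18 log units; within the scatter) is expected to stay within the scatter. The estimate for compound 4 in this assay is 2200 nM, with a range from 1100 nM to 4400 nM.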

Compound 4, half-maximal inhibitory concentration: 1470 nM
The estimate for compound 4 lay 1.5-fold (0.18 log units) above the measured number, within the range that was stated.
By their numbers in this assay, from the lowest: compounds 4, 1, 2 and 3 (each within the scatter of the next, the first and the last beyond it).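

In this assay, the change from benzyl to 3,4-dichlorobenzyl gives a 2.3-fold lower number from compound 3 to compound 4 (0.36 log units; beyond the scatter), the first step from the unsubstituted benzyl compound to a chlorine-bearing one that is beyond the scatter, whereas the step with the 2,4-dichlorophenyl group, a 1.8-fold higher number from compound 2 to compound 3 (0.24 log units; within the scatter), stays within it. The 3,4-dichlorophenyl group cannot be told apart from the other two substituted rings, with a 1.3-fold lower number from compound 2 to compound 4 (0.11 log units; within the scatter) and a 1.0-fold lower number from compound 1 to compound 4 (0.01 log units; within the scatter), so compounds 1, 2 and 4 read as one group at this position, and only compounds 1 and 4 separate from compound 3, with compound 2 going against any rule that every substituted ring lowers the number beyond the scatter. Nothing in hand accounts for the step from phenyl to 3,4-dichlorophenyl.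

As far as these compounds go, whether one chlorine on this ring is enough for such a step, and whether a methoxy group, an amine or a carboxylic acid there would give a similar number, stays open. Also open, from the compounds shown here alone, is how a longer chain in place of the single saturated carbon on the aromatic nitrogen would read in this assay.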